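Sulfur for oxygen in the ring: a second try

The compounds below may be only part of what the source reports. "The series", "measured", "known", "first", "only" and "open" are said of these compounds alone.

Measured so far:
compound 1 `Nc1nnc(-c2ccccc2Sc2ccccc2)o1` — 63.7%
compound 2 `Nc1nnc(-c2ccccc2[S+]([O-])c2ccccc2)o1` — 79.9%
compound 3 `S=c1[nH]nc(-c2ccccc2Sc2ccccc2)[nH]1` — 79.6%

In a functional assay on the whole organism (strain NMRI) for inhibition, with Mus musculus as the target, in the formalin test, with a stated time of 30 min, at a dose of 30 umol/kg by the intraperitoneal route (a lower number here means less inhibition, a higher number more inhibition at the dose given (going by the name of the read-out)), compound 1 gives 63.7%. Compound 3 `S=c1[nH]nc(-c2ccccc2Sc2ccccc2)[nH]1` carries one change on the core of compound 1: a group of 6 heavy atoms (2 carbon, 3 nitrogen, 1 sulfur; one five-membered aromatic ring with 3 hetero atoms) in place of a group of 6 heavy atoms (2 carbon, 3 nitrogen, 1 oxygen; one five-membered aromatic ring with 3 hetero atoms), on an aromatic carbon. This change gave a number 15.9 percentage points higher from compound 1 to compound 3 (beyond the scatter). Compound 2 `Nc1nnc(-c2ccccc2[S+]([O-])c2ccccc2)o1` and compound 3 give numbers that lie within the scatter of each other. The difference between the cores of compound 1 and compound 2 is not broken down here.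

Compound 4 `[O-][S+](c1ccccc1)c1ccccc1-c1n[nH]c(=S)[nH]1` is not yet measured. It differs from compound 2 in this way: a group of 6 heavy atoms (2 carbon, 3 nitrogen, 1 sulfur; one five-membered aromatic ring with 3 hetero atoms) in place of a group of 6 heavy atoms (2 carbon, 3 nitrogen, 1 oxygen; one five-membered aromatic ring with 3 hetero atoms), on an aromatic carbon. The surroundings are not word for word the same as in the step from compound 1 to compound 3. The place of the new group, as set out in the two computed differences, is described a little differently, so this is the same kind of change, not the same change. Compound 4 is expected to gain a number 8.1 percentage points higher from compound 2 to compound 4 (within the scatter), a somewhat smaller step than the earlier one, because compound 2 already gives 79.9% and a percentage cannot rise without end. For compound 4 the estimate in this assay is 88%, within 76% to 98%.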

Compound 4, a percentage reported as inhibition, in the whole organism at one dose (the size of the read-out at that dose, not a potency): 63.3%
Compound 4: the middle estimate sits 24.7 percentage points above what was measured, and the stated range ends above it.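

In this assay, the same exchange of ring that raised the number on the core of compound 1 gave a number 16.6 percentage points lower from compound 2 to compound 4 (beyond the scatter). The change therefore did not carry over from one core to the other, and its direction reversed: the same change on two cores in this assay, a number 15.9 percentage points higher (beyond the scatter) from compound 1 to compound 3 and a number 16.6 percentage points lower (beyond the scatter) from compound 2 to compound 4, 32.5 percentage points apart, beyond the scatter of two such steps
With only these two pairs, this shows that the result of the change depends on the core it is made on, but it does not show what in the core is responsible or give a rule for any other core.

The compounds shown leave open what the same exchange would do with a sulfonyl group in place of the linking sulfur of compound 1. They also leave open whether the reversal would hold at other doses.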